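A few compounds are considered here, and "the series" means these few. Any claim that something is new, unique, unknown or untested is made for them only; others in the source may bear on it.

Working notes on the series. The shared core of compound 1 `Clc1cccc2c(Cc3cc4ccccc4[nH]3)c[nH]c12` carries a chloro on an aromatic carbon; in an assay on HepG2 cells for inhibition of Proprotein convertase subtilisin/kexin type 9 (Homo sapiens), read by AlphaLISA, with a stated time of 48 h (on this read-out lower numbers stand for stronger inhibition and higher numbers for weaker inhibition), compound 1 gives 2800 nM. Among the measured compounds shown here, compound 2 `Cc1cccc2c(Cc3cc4ccccc4[nH]3)c[nH]c12` gives 900 nM, and the step of a 3.1-fold lower number from compound 1 to compound 2 (0.49 log units; beyond the scatter) is the one clear change so far. Compound 3 `Cc1ccc(S(=O)(=O)n2c(Cc3c[nH]c4c(Cl)cccc34)c(C)c3ccccc32)cc1`, with the sulfonyl-bearing core, gives 2300 nM; compound 3 and compound 1 give numbers that lie within the scatter of each other, while compound 2 gives the lower number of the three, beyond the scatter from compound 3.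

The next step goes from compound 3 to compound 4 `Cc1ccc(S(=O)(=O)n2c(Cc3cn(C)c4ccccc34)c(C)c3ccccc32)cc1`: 1-methyl-1H-indol-3-yl in place of 7-chloro-1H-indol-3-yl on a saturated chain carbon bound to an aromatic carbon. For the measured compounds named here, the only measured step bearing on it is the exchange of chloro for methyl at an aromatic carbon, a 3.1-fold lower number from compound 1 to compound 2 (0.49 log units; beyond the scatter), a modest gain. Compound 4 also loses the chloro, but the methyl instead enters on the ring nitrogen, for which no comparison exists. A modest drop in the number is therefore expected, with wide uncertainty, a 1.5-fold lower number from compound 3 to compound 4 (0.19 log units; within the scatter). For compound 4 the expected value is 1500 nM, within 500 nM to 4500 nM.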

Compound 4, half-maximal inhibitory concentration: 1500 nM
Estimate against measurement, compound 4: no gap at the digits printed; the range from low to high includes it.
By their numbers in this assay, from the lowest: compounds 2, 4, 3 and 1 (each within the scatter of the next, the first and the last beyond it).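

In this assay the exchange of 7-chloro-1H-indol-3-yl for 1-methyl-1H-indol-3-yl on a saturated chain carbon bound to an aromatic carbon gives a 1.5-fold lower number from compound 3 to compound 4 (0.19 log units; within the scatter) and so does not separate the two compounds. This position therefore accepts a group without the chloro, and without the hydrogen-bond donor counted on the leaving group, with no change beyond the scatter in this sulfonyl-bearing core. No supporting measurement bears on this result.

The exchange alters the chloro and the methyl together, so the compounds shown do not give the contribution of either one alone. Also open, going by these compounds, is how an amine or a carboxylic acid would read in place of the indolyl group on that saturated chain carbon.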